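The source may report more compounds than this note shows. Statements on the series, on what has been measured and on what is new or still open speak of the compounds shown alone.

Three compounds share one core and differ only in what sits on the six-membered aromatic ring of carbon only at its far end. Compound 1 `CC1(C)[C@H]2CC[C@]1(C)N(Cc1cn(-c3ccccc3O)nn1)C(=O)C2` carries a hydroxy there and in a functional assay on A549 cells (Homo sapiens) for inhibition, read by MTT assay, with a stated time of 24 h (on this read-out lower numbers stand for stronger inhibition and higher numbers for weaker inhibition), compound 1 gives 230 nM. Compound 2 `COc1ccccc1-n1cc(CN2C(=O)C[C@@H]3CC[C@@]2(C)C3(C)C)nn1` carries a methoxy in the same place, and in this assay compound 2 gives 350 nM; the step of a 1.5-fold higher number from compound 1 to compound 2 (0.18 log units; within the scatter) separates them. Compound 3 `CC1(C)[C@H]2CC[C@]1(C)N(Cc1cn(-c3ccccc3)nn1)C(=O)C2` has only hydrogen on that ring, and in this assay compound 3 gives 70 nM, the lowest of the three numbers: the steps of a 3.3-fold lower number from compound 1 to compound 3 (0.52 log units; beyond the scatter) and a 5.0-fold lower number from compound 2 to compound 3 (0.70 log units; beyond the scatter) both lie beyond the scatter.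

Compound 4 `CC1(C)[C@H]2CC[C@]1(C)N(Cc1cn(-c3ccccc3Cl)nn1)C(=O)C2` is the next step from compound 3: chloro in place of hydrogen on an aromatic carbon. Within the data shown here, no measured pair adds a chloro, so only the hydroxy and methoxy steps bear on it, and both show that placing a group on that aromatic carbon raised the number by a modest amount. A chloro is a different kind of group, so the expectation is weaker than for either measured one. Compound 4 is therefore expected to give a somewhat higher number than compound 3, a step of about a 2.1-fold higher number from compound 3 to compound 4 (0.33 log units; beyond the scatter), and the estimate for compound 4 in this assay is 150 nM, with a range from 50 nM to 450 nM.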

Compound 4, half-maximal inhibitory concentration: 70 nM
The estimate for compound 4 lay 2.1-fold (0.33 log units) above the measured number, and the stated range covers the measured number.
By their numbers in this assay, from the lowest: compounds 3 and 4 (each within the scatter of the next); then compounds 1 and 2 (each within the scatter of the next).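

The earlier compounds shown here could suggest that any group on this aromatic carbon gives a higher number than hydrogen, but in this assay chloro breaks that reading, with no change at the digits printed from compound 3 to compound 4 (within the scatter) as the step. The hydroxy and methoxy compounds now stand apart from chloro as well as from hydrogen, with a 5.0-fold lower number from compound 2 to compound 4 (0.70 log units; beyond the scatter) and a 3.3-fold lower number from compound 1 to compound 4 (0.52 log units; beyond the scatter) as the steps, so the higher numbers of compound 1 and compound 2 go with those two groups and not with the mere presence of a group at this place. Nothing available here explains why chloro behaves like hydrogen at this place while hydroxy and methoxy do not.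

Among these compounds, with only three groups compared against hydrogen, it remains open whether the oxygen attached to the ring is what separates compound 1 and compound 2 from compound 4, and an amine, a methyl or a fluoro at the same place would help to tell. On these data alone, it is also open whether a chloro elsewhere on this ring, or a larger group such as a longer chain, would stay as close to compound 3.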